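Ring Size on the Urea Nitrogen: Compound 3 to Compound 4

The source may hold more compounds than are shown below. What is called first, only, known or untested is meant among the compounds shown, and "the series" means these compounds.

Measured compounds:
- compound 1 `Cc1cc(C)c(NC(=O)N(Cc2cc(-c3ccccc3)cs2)C2CCCCCC2)c(C)c1`: < 1 mg/kg
- compound 2 `Cc1cc(C)c(NC(=O)N(Cc2ccc(-c3ccccc3)o2)C2CCCCCC2)c(C)c1`: < 1 mg/kg
- compound 3 `Cc1cc(C)c(NC(=O)N(Cc2cccc(-c3cc[nH]n3)c2)C2CCCCC2)c(C)c1`: 0.12 mg/kg

All three share a urea core carrying a trimethylphenyl group and were tested in a functional assay on a cell-free system (plasma) with sterol O-acyltransferase, Soat (Rattus norvegicus) as the target; a higher number here means that more compound is needed for the effect, a lower number that less compound is needed. For compound 1 the value < 1 mg/kg is a limit of the assay, not a number. For compound 2 the value < 1 mg/kg is likewise a limit. Going by the values given here, compound 3 is therefore the only compound with a measured number, 0.12 mg/kg in this assay; the other two sit at the limit of < 1 mg/kg in this assay, at which 2 of the 3 values shown sit, so no step between measured compounds can be computed, and no ordering among them can be claimed.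

Compound 4 `Cc1cc(C)c(NC(=O)N(Cc2cccc(-c3cc[nH]n3)c2)C2CCCC2)c(C)c1` is the next compound and is not yet measured. It differs from compound 3 in one place: cyclopentyl in place of cyclohexyl on an amide-type nitrogen. A change of one carbon in a saturated ring is expected to give a small step, likely within or just beyond the usual scatter, and if anything toward needing more compound. Compound 4 is therefore estimated at 0.2 mg/kg, in a range from 0.06 mg/kg to 0.7 mg/kg, meaning an expected step of a 1.7-fold higher number from compound 3 to compound 4 (0.22 log units; within the scatter).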

Compound 4, dose for half-maximal effect: < 1 mg/kg
Compound 4 gave a limit, no number; the forecaster's own chance of this, stated with the estimate: 10%; the middle value is on the limit's open side.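

In this assay compound 4 gives < 1 mg/kg, which is a limit of the assay and not a number. No step can be read between compound 3 and compound 4. Still open is whether cyclopentyl in place of cyclohexyl on an amide-type nitrogen changes the dose needed, and how the compounds at the limit rank: the limit of < 1 mg/kg in this assay, at which 3 of the 4 values shown sit.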